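Replacing the Pyridyl Ketone with a Bromothiophene Ketone

A few compounds are considered here, and "the series" means these few. Any claim that something is new, unique, unknown or untested is made for them only; others in the source may bear on it.

Measured compounds:
- Compound 1, `COc1ccc(-c2cc3ccccc3nc2/C=C/C(=O)c2ccc(O)cc2)cc1`: 3880 nM
- Compound 2, `COc1ccc(-c2cc3ccccc3nc2/C=C/C(=O)c2ccccn2)cc1`: 370 nM

Among the compounds with values here, compound 2 gives the lowest number of the two measured compounds in a functional assay on SK-BR-3 cells (Homo sapiens) for antiproliferative activity, read by XTT assay, with a stated time of 72 h; on this read-out higher numbers stand for weaker inhibition and lower numbers for stronger inhibition; its nearest neighbour is compound 1, and the only measured step, a 10-fold lower number from compound 1 to compound 2 (1.02 log units; beyond the scatter), lies beyond the scatter. That step shows that the aromatic group on the carbonyl carbon can shift the read-out strongly.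

Compound 3, `COc1ccc(-c2cc3ccccc3nc2/C=C/C(=O)c2ccc(Br)s2)cc1`, is not yet measured. It differs from compound 2 in one place: 5-bromothiophen-2-yl in place of pyridin-2-yl on a carbonyl carbon. Within the data shown here, no measured step covers this exact exchange; the one step that exists concerns the same position but a different pair of groups. It tells only that the position is sensitive, not in which direction a five-membered ring carrying bromine will move the number. A moderate change in either direction is therefore plausible, with a wide range.

Compound 3 is expected to give roughly 800 nM in this assay, within 200 nM to 4000 nM, which is estimated to mean a 2.2-fold higher number from compound 2 to compound 3 (0.33 log units; beyond the scatter).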

Compound 3, half-maximal inhibitory concentration: 520 nM
Compound 3: the middle estimate sits 1.5-fold (0.19 log units) above what was measured, within the range that was stated.
By their numbers in this assay, from the lowest: compounds 2 and 3 (each within the scatter of the next); then compound 1.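

In this assay, the exchange of pyridin-2-yl for 5-bromothiophen-2-yl on the carbonyl carbon gives a 1.4-fold higher number from compound 2 to compound 3 (0.15 log units; within the scatter), so this position accepts a five-membered aromatic ring carrying bromine as readily as the six-membered ring of compound 2, and a ring nitrogen is not required for a number in this range. The second step, a 7.5-fold lower number from compound 1 to compound 3 (0.87 log units; beyond the scatter), shows that the large step seen earlier was not unique to pyridin-2-yl: two different hetero rings now stand apart from the 4-hydroxyphenyl group of compound 1, while compound 2 and compound 3 cannot be told apart in this assay. Nothing available explains why these groups read as they do.

The compounds shown leave open what the bromine and the thiophene ring each contribute, a question that a thiophen-2-yl ketone without bromine or one with chlorine in its place would address. They also leave open whether the distance of compound 1 from the others belongs to its hydroxyl group or to its phenyl ring, which an unsubstituted phenyl or a 4-aminophenyl group on the same carbonyl carbon would begin to separate.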